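This account rests on a few compounds, and the source may have more. Where it says the series, first, only, none or still open, it means among the compounds named here.

Measured so far:
Compound 1 `CCn1cc(C(=O)O)c(=O)c2cc(F)c(N3CCN(C(=N)NS(=O)(=O)c4ccc(C(F)(F)F)cc4)CC3)cc21`: 43 nM
Compound 2 `CCn1cc(C(=O)O)c(=O)c2cc(F)c(N3CCN(C(=N)NS(=O)(=O)c4ccccc4Cl)CC3)cc21`: 43 nM

In a functional assay on HL-60 cells (Homo sapiens) for antiproliferative activity, read by MTT assay, with a stated time of 72 h (a higher number here means a weaker inhibitor, a lower number a stronger inhibitor), compound 2 gives 43 nM, level with compound 1 at 43 nM. Compound 3 `CCn1cc(C(=O)O)c(=O)c2cc(F)c(N3CCN(C(=N)NS(=O)(=O)c4ccccc4)CC3)cc21` differs from compound 2 by hydrogen in place of chloro on an aromatic carbon. Among the measured compounds shown here, only one measured step bears on this ring: no change at the digits printed from compound 1 to compound 2 (within the scatter). It changed the ring's substitution without moving the value beyond the scatter, but neither measured compound carries a plain phenyl, so this is only weak guidance. The expected step is a 1.0-fold higher number from compound 2 to compound 3 (0.02 log units; within the scatter), with no change beyond the scatter and no favoured direction. For compound 3 the estimate is 45 nM, with an expected range of 18 nM to 110 nM.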

Compound 3, half-maximal inhibitory concentration: 43 nM
Compound 3: the middle estimate sits 1.0-fold (0.02 log units) above what was measured; measured number inside the range.
By their numbers in this assay, from the lowest: compounds 1, 2 and 3 (each within the scatter of the next).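

Compound 3 gives this ring its unsubstituted reference point. In this assay, hydrogen in place of chloro gives no change at the digits printed from compound 2 to compound 3 (within the scatter), and hydrogen in place of trifluoromethyl gives no change at the digits printed from compound 1 to compound 3 (within the scatter). Among these three compounds, therefore, neither the 2-chlorophenyl nor the 4-(trifluoromethyl)phenyl group moves the value beyond the scatter compared with phenyl, and activity at this level does not need either substituent.

Going by these compounds, whether an amine or a carboxylic acid on this ring would also leave the value in place remains open. Nothing available accounts for the matching values.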